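The source may report more compounds than this note shows. Statements on the series, on what has been measured and on what is new or still open speak of the compounds shown alone.

Compound 1 `CCCCc1nc(C(C)C)c(CC(=O)OC)c(=O)n1Cc1ccc(-c2ccccc2-c2noc(=O)[nH]2)cc1` and compound 2 `CCCCc1nc(C(C)C)c(CC(=O)OC(CC)CC)c(=O)n1Cc1ccc(-c2ccccc2-c2noc(=O)[nH]2)cc1` share one core and differ only in the ester alkyl group. In an ADME assay on microsomes from liver (Homo sapiens) for metabolic stability, with a stated time of 30 min (a higher number here means that more of the compound is left, a lower number that less of the compound is left), compound 1 gives 10.5%, and in the same assay compound 2 gives 7.7%. The step of a number 2.8 percentage points lower from compound 1 to compound 2 (within the scatter) is the only measured step in the set, and on the two numbers shown compound 2 holds the lower position, though within the scatter of compound 1.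

Compound 3 `CC#CCOC(=O)Cc1c(C(C)C)nc(CCCC)n(Cc2ccc(-c3ccccc3-c3noc(=O)[nH]3)cc2)c1=O` carries the change (but-2-yn-1-yl in place of pentan-3-yl on an oxygen next to a carbonyl group). For the measured compounds named here, the one measured step, from methyl to pentan-3-yl on the same oxygen, bears on it and stayed within the scatter, so the ester alkyl group has so far not moved the remaining fraction in this assay beyond noise. No step beyond the scatter is therefore expected in this assay for compound 3, and the estimated step is a number 1.3 percentage points higher from compound 2 to compound 3 (within the scatter). For compound 3 the expected value in this assay is 9%, with a range from 3% to 18%.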

Compound 3, percent of the compound remaining: 13.7%
Compound 3: middle estimate off by 4.7 percentage points, on the low side; measured number inside the range.
By their numbers in this assay, from the lowest: compounds 2, 1 and 3 (each within the scatter of the next).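

On the oxygen next to a carbonyl group, but-2-yn-1-yl in place of pentan-3-yl in this assay gives a number 6 percentage points higher from compound 2 to compound 3 (within the scatter) and so adds a group with a triple bond to the saturated groups seen so far at this place. Compared with the methyl ester, the same group, read here as prop-1-yn-1-yl in place of hydrogen on a saturated chain carbon bound to that oxygen, gives a number 3.2 percentage points higher from compound 1 to compound 3 (within the scatter) and so also leaves the read-out within noise, meaning that methyl, pentan-3-yl and but-2-yn-1-yl cannot be told apart in this assay. No measurement at hand speaks to the origin of these numbers.

Still open, on these data alone, is whether any group on this oxygen, such as benzyl or a longer chain, or a carboxylic acid or an amide in place of the ester, moves the remaining fraction beyond the scatter. Also open, as far as these compounds go, is whether a change elsewhere on the shared core bears on this read-out.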